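The compounds below may be only part of what the source reports. "The series", "measured", "known", "first", "only" and "open" are said of these compounds alone.

In a functional assay on CCRF-HSB-2 cells (Homo sapiens) for antiproliferative activity (a lower number here means a stronger inhibitor, a higher number a weaker inhibitor), compound 1 `CCc1cn([C@@H]2S[C@H](CO)[C@@H](O)[C@@H]2O)c(=O)[nH]c1=O` gives > 100 ug/mL, which is a limit of the assay and not a number. Compound 2 `Cc1cn([C@@H]2S[C@H](CO)[C@@H](O)[C@@H]2O)c(=O)[nH]c1=O` gives > 100 ug/mL, also a limit. Compound 3 `CCc1cn([C@H]2S[C@H](CO)[C@@H](O)[C@@H]2O)c(=O)[nH]c1=O` gives > 100 ug/mL, again a limit. Compound 2 therefore shares (the limit of > 100 ug/mL in this assay, at which 3 of the 3 values shown sit).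

Compound 4 `O=c1[nH]c(=O)n([C@@H]2S[C@H](CO)[C@@H](O)[C@@H]2O)cc1I` differs from compound 2 by one group: iodo in place of methyl on an aromatic carbon. This places iodo in place of methyl on an aromatic carbon. Two measured steps offer guidance, but neither gives a size. Within the data shown here, the first is a step that the two limits leave unreadable from compound 1 to compound 2. The second is a step that the two limits leave unreadable from compound 1 to compound 3, and it reflects (the fact that compounds 1 and 3 differ only in the configuration as drawn), so it says nothing about exchanging a group. Among the measured compounds shown here, no iodo compound has yet been measured here, so the data support no firm direction. The expected result is that compound 4 stays close to the limit of the assay, although a readable number remains possible. The estimated change is a number no higher from compound 2 to compound 4 (the limit leaves the size open). For compound 4, the expected value in this assay is 100 ug/mL, with an estimated range of 20 ug/mL to 300 ug/mL.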

Compound 4, half-maximal inhibitory concentration: > 100 ug/mL
Compound 4: only a limit was reported; the forecaster's own chance of this, stated with the estimate: 65%; the middle value lies on the limit itself.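

In this assay compound 4 gives > 100 ug/mL, a limit and not a number, so its steps from compound 1 and compound 2 cannot be read. The compounds shown leave open which change to the shared core, if any, would give a readable number, as every result so far sits at: the limit of > 100 ug/mL in this assay, at which 4 of the 4 values shown sit.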